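Changing the aryl group on the amide: compound 3 to compound 4

The source may report more compounds than this note shows. Statements on the series, on what has been measured and on what is new or still open speak of the compounds shown alone.

- compound 1 `CN(C)C(=O)c1cc2cnc(Nc3ccc(NC(=O)C4(C(=O)Nc5cccc(F)c5)CC4)cc3)nc2n1C1CCCC1`: 91.8%
- compound 2 `CN(C)C(=O)c1cc2cnc(Nc3ccc(NC(=O)C4(C(=O)Nc5ccccc5F)CC4)cc3)nc2n1C1CCCC1`: 88.6%
- compound 3 `CN(C)C(=O)c1cc2cnc(Nc3ccc(NC(=O)C4(C(=O)Nc5cccc(C(F)(F)F)c5)CC4)cc3)nc2n1C1CCCC1`: 89.2%

These values come from a functional assay on A549 cells (Homo sapiens) for inhibition, read by CCK-8 assay, with a stated time of 72 h, tested at 10 uM; on this read-out higher numbers stand for more inhibition of growth at the one concentration tested and lower numbers for less inhibition of growth. On this read-out, compound 3 at 89.2% cannot be told apart from compound 1 or compound 2, since all three values lie within the scatter of one another.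

The next molecule, compound 4 `CN(C)C(=O)c1cc2cnc(Nc3ccc(NC(=O)C4(C(=O)Nc5ccc(C#N)cc5)CC4)cc3)nc2n1C1CCCC1`, has 4-cyanophenyl in place of 3-(trifluoromethyl)phenyl on an amide-type nitrogen. Three measured steps changed this same aryl group: a number 3.2 percentage points lower from compound 1 to compound 2 (within the scatter), a number 2.6 percentage points lower from compound 1 to compound 3 (within the scatter) and a number 0.6 percentage points higher from compound 2 to compound 3 (within the scatter). Going by the values given here, all three are small, but none of the measured compounds carries a 4-cyanophenyl group, so they are only an indirect guide. A clear step in this assay is therefore not expected, though the range allows more room for a loss.

The expected change is a number 3.2 percentage points lower from compound 3 to compound 4 (within the scatter).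

Compound 4 is estimated to give 86%, within a range of 72% to 94%.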

Compound 4, percent growth inhibition at one concentration: 95%
The estimate for compound 4 lay 9 percentage points below the measured number, and the stated range ends below it.
By their numbers in this assay, from the lowest: compounds 2, 3, 1 and 4 (each within the scatter of the next).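

In this assay, going by these compounds alone, the earlier compounds varied only fluoro and trifluoromethyl groups on the aryl ring, while compound 4 brings a nitrile, and the steps to it from all three remain small (a number 5.8 percentage points higher from compound 3 to compound 4 (within the scatter)), (a number 6.4 percentage points higher from compound 2 to compound 4 (within the scatter)) and (a number 3.2 percentage points higher from compound 1 to compound 4 (within the scatter)). This position on the amide-type nitrogen therefore accepts 4-cyanophenyl, with its triple bond and hydrogen-bond acceptor, without any step beyond the scatter among these four compounds. Nothing measured here offers an explanation for these results.

Still open, from the compounds shown here alone, is whether an aryl ring bearing an amine or a carboxylic acid, or a longer alkyl chain in place of the ring, would fit this pattern. With only one concentration tested, these compounds also cannot show whether the four aryl groups would separate at lower concentrations.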